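Compound 2 without one methoxy group: an expected loss

The source may hold more compounds than are shown below. What is called first, only, known or untested is meant among the compounds shown, and "the series" means these compounds.

In a functional assay on CCRF-CEM cells (Homo sapiens) for antiproliferative activity (a higher number here means a weaker inhibitor, a lower number a stronger inhibitor), compound 1 `COc1ccc(OC)c(C(=O)c2ccc3c(ccn3C)c2)c1` gives 2370 nM and compound 2 `COc1ccc(C(=O)c2ccc3c(ccn3C)c2)c(OC)c1` gives 102 nM as the lower of the two numbers. The gap between them lies beyond the usual scatter, so compound 2 stands as the stronger of the pair. Both carry two methoxy groups on the shared core, placed differently.

The next structure is compound 3 `COc1ccc(C(=O)c2ccc3c(ccn3C)c2)cc1`. The change from compound 2 is hydrogen in place of methoxy on an aromatic carbon and amounts to hydrogen in place of methoxy on an aromatic carbon, ortho to a large group. Going by the values given here, the series holds no measured step for the loss of a single methoxy group, so the expectation is only loosely supported. Compound 2 at 102 nM and compound 1 at 2370 nM show that the number can differ widely among close relatives, which argues for a wide range. In this assay the expected move is a 3.9-fold higher number from compound 2 to compound 3 (0.59 log units; beyond the scatter) as an estimate, toward a higher number and beyond the scatter. Compound 3 is estimated at 400 nM with an expected range from 100 nM to 2000 nM for the measurement still to come.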

Compound 3, half-maximal inhibitory concentration: 1130 nM
Compound 3: the middle estimate sits 2.8-fold (0.45 log units) below what was measured, within the range that was stated.
By their numbers in this assay, from the lowest: compound 2; then compound 3; then compound 1.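

In this assay, going by these compounds alone, replacing the methoxy group ortho to a large group with hydrogen gives an 11-fold higher number from compound 2 to compound 3 (1.04 log units; beyond the scatter), the first step that changes a single place. The other methoxy group stays in both compounds, so this large step belongs to this one position and this one change, whereas the earlier pair differed only in how two methoxy groups were placed. No supporting data bear on why the step is this large.

The compounds shown give only one substituent and hydrogen at this position, so it remains open whether the gain in compound 2 is specific to methoxy or would also appear with a hydroxyl group, an ethoxy group or a fluorine atom there. As far as these compounds go, it is equally open whether the same change would give a step of similar size on a ring carrying a different second group, since this single pair cannot show whether the effect of the position holds beyond compound 2 and compound 3.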